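The source may report more compounds than this note shows. Statements on the series, on what has been measured and on what is new or still open speak of the compounds shown alone.

Compound 1 `O=c1oc2ccccc2c2nc3c(ccc4cc[nH]c43)c(-c3ccc(Cl)cc3)c12`: 70700 nM in a functional assay on B16-F10 cells (Mus musculus) for cytotoxicity; on this read-out lower numbers stand for stronger inhibition and higher numbers for weaker inhibition
Compound 2 `O=c1oc2ccccc2c2nc3c(ccc4cc[nH]c43)c(-c3ccc(Cl)cc3Cl)c12`: 70700 nM in this assay

These two compounds share a core and differ only in the chloro in place of hydrogen on an aromatic carbon, and across that step the read-out was no change at the digits printed from compound 1 to compound 2 (within the scatter). Compound 2 therefore stands level with compound 1 on the numbers shown, both giving the same weak figure in this assay.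

Compound 3 `Cc1ccc(-c2c3ccc4cc[nH]c4c3nc3c2c(=O)oc2ccccc23)cc1` carries 4-methylphenyl in place of 2,4-dichlorophenyl on an aromatic carbon. Among the compounds with values here, the only measured step bears on this change only loosely: swapping a hydrogen for a chlorine on the same aromatic ring gave no shift beyond the scatter. The change to compound 3 is larger, exchanging both chlorines for a single methyl, but the data give no sign that this ring governs the read-out. In this assay, the step from compound 2 to compound 3 is therefore expected to be no change at the digits printed from compound 2 to compound 3 (within the scatter), no change beyond the scatter. Compound 3 is estimated at 70700 nM, expected to fall between 30000 nM and 100000 nM.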

Compound 3, half-maximal inhibitory concentration: 70700 nM
Compound 3: the middle estimate sits on the measured number at the digits printed; measured number inside the range.
By their numbers in this assay, from the lowest: compounds 1, 2 and 3 (each within the scatter of the next).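

In this assay, the step to a ring with no chlorine at all is small (no change at the digits printed from compound 2 to compound 3 (within the scatter)), and so is the direct swap of methyl for chloro on the ring (no change at the digits printed from compound 1 to compound 3 (within the scatter)). The earlier pair showed only that adding a second chlorine left the figure in place, whereas these steps show that the aryl group on this aromatic carbon, opposite the ring nitrogen, can carry a methyl or one or two chlorines with no change beyond the scatter. Nothing available explains why these three figures coincide.

Still open, on these data alone, is whether a 4-aminophenyl or 4-carboxyphenyl group, or a longer alkyl chain in place of the aryl ring, would move the number at this position. Also open, as far as these compounds go, is whether changes elsewhere on the shared core would move it.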